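This account rests on a few compounds, and the source may have more. Where it says the series, first, only, none or still open, it means among the compounds named here.

Measured in a functional assay on KB cells (Homo sapiens) for inhibition; a lower number here means a stronger inhibitor, a higher number a weaker inhibitor:
Compound 1, `CNc1nc2cc(Cl)c(Cl)cc2n1COCCO`, gives > 100000 nM, which is a limit of the assay and not a number.
Compound 2, `OCCOCn1c(SCc2ccccc2)nc2cc(Cl)c(Cl)cc21`, gives 55000 nM.
Compound 3, `CNc1nc2c(Cl)cc(Cl)cc2n1COCCO`, gives > 100000 nM, again a limit of the assay and not a number.

From compound 1 to compound 2 the change is benzylsulfanyl in place of methylamino on an aromatic carbon. This step gave an at least 1.8-fold lower number from compound 1 to compound 2 (0.25 log units; that floor lies within the scatter); its size is known only as a floor because of the limit of > 100000 nM in this assay, at which 2 of the 3 values shown sit. Compound 3 is built from the same atoms as compound 1, joined differently; the difference between the two cores is not broken down here. Compound 4, `OCCOCn1c(SCc2ccccc2)nc2c(Cl)cc(Cl)cc21`, has not yet been measured in this assay. It stands to compound 3 as compound 2 stands to compound 1, through (benzylsulfanyl in place of methylamino on an aromatic carbon), the same change at the same place. The expectation for compound 4 rests on compound 2 and its step of an at least 1.8-fold lower number from compound 1 to compound 2 (0.25 log units; that floor lies within the scatter). It also rests on compound 3, whose > 100000 nM is a limit of the assay, so the starting point is itself uncertain. Compound 4 is expected to show an at least 1.6-fold lower number from compound 3 to compound 4 (0.22 log units; that floor lies within the scatter). The estimate for compound 4 is 60000 nM, with a range from 25000 nM to 150000 nM.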

Compound 4, half-maximal inhibitory concentration: > 100000 nM
Compound 4: a limit, no number (the forecaster's own chance of this, stated with the estimate: 35%); middle value at least 1.6-fold (0.22 log units) from the limit.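

Compound 3 and compound 4 both sit at a limit of the assay and not at a number, so the step between them cannot be read: the limit of > 100000 nM in this assay, at which 3 of the 4 values shown sit.

The compounds shown leave open whether benzylsulfanyl in place of methylamino changes the number at all on the core of compound 3, and how far past the limit compound 3 and compound 4 lie.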